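The source may report more compounds than this note shows. Statements on the series, on what has been measured and on what is new or still open speak of the compounds shown alone.

In an assay on HEK293 cells for positive allosteric modulation of metabotropic glutamate receptor 2 (Rattus norvegicus), read by thallium flux, with a stated time of 2.5 min (a lower number here means a smaller maximal response, a higher number a larger maximal response), compound 3, `CC(=O)c1ccc(OCCCCOc2ccc(F)c(C(=O)O)c2)c(C)c1O`, gives 75.5%. Among the three measured compounds this is the second highest number. Compound 2, `CCC(=O)c1ccc(OCCCCOc2ccc(F)c(C(=O)O)c2)c(C)c1O`, is the nearest and gives 66.6%; the step of a number 8.9 percentage points higher from compound 2 to compound 3 (within the scatter) separates the two. Compound 1, `Cc1c(OCCCCOCOc2ccc(C(=O)O)cc2)ccc(C(=O)CC2CCCC2)c1O`, is the furthest and gives 95.4%; compound 1 differs from compound 3 in more than one place, so only its value stands beside that of compound 3.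

Compound 4, `Cc1c(OCCCCOc2ccc(F)c(C(=O)O)c2)ccc(C(=O)CC2CCCC2)c1O`, is not yet measured. It differs from compound 3 in one place: cyclopentyl in place of hydrogen on a saturated chain carbon bound to a carbonyl carbon. Within the data shown here, only one measured step touches the same place, a hydrogen entering for a methyl on the saturated chain carbon bound to the carbonyl carbon, and that step was a number 8.9 percentage points higher from compound 2 to compound 3 (within the scatter). Among the measured compounds shown here, no measured step shows a cyclopentyl entering there on its own. Compound 1 carries that cyclopentyl and gives 95.4%, yet it also differs elsewhere, so it offers only a loose hint upward.

For compound 4 a largest response of 85% is therefore expected, between 68% and 100%. The step of a number 9.5 percentage points higher from compound 3 to compound 4 (within the scatter) is estimated to be modest, near the edge of the scatter.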

Compound 4, largest response reached (reported as percent of maximum), in percent of the reference or control that the assay uses: 81%
Compound 4: the middle estimate sits 4 percentage points above what was measured, and the stated range covers the measured number.
By their numbers in this assay, from the lowest: compounds 2, 3 and 4 (each within the scatter of the next, the first and the last beyond it); then compound 1.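

Cyclopentyl in place of hydrogen on the saturated chain carbon bound to the carbonyl carbon gives, in this assay, a number 5.5 percentage points higher from compound 3 to compound 4 (within the scatter), so this place accepts a five-membered carbon ring and the maximal response stays within the usual scatter of the hydrogen compound. Set against the methyl group, however, the same ring gives a number 14.4 percentage points higher from compound 2 to compound 4 (beyond the scatter), and this is the only step at this place that clears the scatter. With the cyclopentyl held constant, 3-carboxy-4-fluorophenyl in place of (4-carboxyphenoxy)methyl on an oxygen on a saturated carbon gives a number 14.4 percentage points lower from compound 1 to compound 4 (beyond the scatter), which shows that the response also depends on this second part of the molecule.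

Nothing at hand explains why any of these steps has its size. The compounds shown leave open whether cyclohexyl, a plain longer chain or an amine at the same place would give a response like that of the cyclopentyl, and whether a group carrying a ring is needed at all.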